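The compounds below may be only part of what the source reports. "The series", "measured", "known", "first", "only" and "open" are said of these compounds alone.

Measured compounds:
Compound 1, `O=C(NCc1ccccc1)Nc1nn(-c2ccccc2)c(=O)c2ccccc12`: 20%
Compound 2, `Nc1nn(-c2ccccc2)c(=O)c2ccccc12`: 24%

Of the compounds shown here, two share one core and have been measured in an assay on CHO cells for displacement of a labelled ligand from adenosine receptor A1 (Homo sapiens), tested at 10 uM; a lower number here means less inhibition, a higher number more inhibition at the concentration tested (going by the name of the read-out). Compound 1 carries a benzyl urea on the core and gives 20%. Compound 2 carries a free amino group in that place and gives 24%. These two numbers lie within the scatter of each other, so on the numbers shown compound 1 stands level with compound 2, and the urea has made no difference that can be told from noise.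

Compound 3, `COc1ccccc1CNC(=O)Nc1nn(-c2ccccc2)c(=O)c2ccccc12`, is not yet measured. It differs from compound 1 in one place: methoxy in place of hydrogen on an aromatic carbon. For the measured compounds named here, with no step between measured compounds to lean on, the expected change from compound 1 to compound 3 is a number 2 percentage points higher from compound 1 to compound 3 (within the scatter), that is, none beyond the scatter. Compound 3 is estimated at 22%, with a range from 5% to 45%.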

Compound 3, a percentage reported as inhibition, at one concentration (the size of the read-out at that concentration, not a potency): 28%
For compound 3 the middle estimate is 6 percentage points below the measured one; the measured number falls inside the stated range.
By their numbers in this assay, from the lowest: compounds 1, 2 and 3 (each within the scatter of the next).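

In this assay, the change from benzyl to 2-methoxybenzyl on the urea gives a number 8 percentage points higher from compound 1 to compound 3 (within the scatter) and so cannot be told from noise. For the compounds shown here, this is the first look at the aromatic ring of the benzyl group, which the comparison of compound 1 with its free amino counterpart could not give, and it shows that methoxy on this aromatic carbon, ortho to a large group, leaves no change beyond the scatter. Nothing shown here offers an explanation for this result.

Still open, going by these compounds, is whether a group of another kind at this same place, such as an amine or a carboxylic acid, would move the number beyond the scatter. Also open, on these data alone, is what a longer chain in place of methoxy, or a methoxy elsewhere on that ring, would do.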